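A few compounds are considered here, and "the series" means these few. Any claim that something is new, unique, unknown or untested is made for them only; others in the source may bear on it.

Measured so far:
compound 1, `N=C(N)NCCC[C@H](NC(=O)CN(c1nc(Cl)nc2[nH]cnc12)C1CC1)C(=O)OCc1ccccc1`: 23.2%
compound 2, `C[C@H](NC(=O)CN(c1nc(Cl)nc2[nH]cnc12)C1CC1)C(=O)O`: 48.1%
compound 3, `CC[C@H](C)[C@H](NC(=O)CN(c1ncnc2c1ncn2C1CCCCO1)C1CC1)C(=O)OCc1ccccc1`: 25.6%

All three were tested in a functional assay on the whole organism (Tail, strain ICR) with Mus musculus as the target, in the tail flick test, with a stated time of 30 min, at a dose of 25 umol/kg by the oral route; on this read-out higher numbers stand for a stronger effect at the one dose given and lower numbers for a weaker effect. Compound 1 gives the lowest of the three numbers, 23.2%. Its nearest neighbour is compound 3, which gives 25.6%, a figure that lies within the scatter of the read-out, so the two cannot be ordered. Compound 2 stands furthest away with 48.1%, a gap beyond the scatter, so compound 2 is clearly stronger than compound 1 on this measure.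

Compound 4, `CC(C)C[C@H](NC(=O)CN(c1nc(Cl)nc2[nH]cnc12)C1CC1)C(=O)OCc1ccccc1`, has not been tested. It differs from compound 1 in one place: a group of 3 heavy atoms (3 carbon; no ring) in place of a group of 6 heavy atoms (3 carbon, 3 nitrogen; no ring), on a saturated chain carbon, two bonds along the chain from an amide-type nitrogen and a carbonyl carbon. The shared core, the cyclopropyl group and the benzyl ester are kept; only the side chain on the saturated chain carbon is exchanged.

For the measured compounds named here, no measured pair isolates this exchange, so the size of the step from compound 1 to compound 4 is open. Compound 3, which also carries a branched alkyl side chain in this position but a different core, gives 25.6%, close to compound 1. On that basis the expected step of a number 6.8 percentage points higher from compound 1 to compound 4 (within the scatter) is small, if anything slightly upward, and may well lie within the scatter. Compound 4 is therefore estimated at 30%, with a range from 15% to 50%.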

Compound 4, a percentage reported as activity, at one dose (the size of the read-out at that dose, not a potency): 33.9%
Estimate against measurement, compound 4: 3.9 percentage points below; the range from low to high includes it.
By their numbers in this assay, from the lowest: compounds 1, 3 and 4 (each within the scatter of the next, the first and the last beyond it); then compound 2.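

For the compounds shown here, for the first time a single exchange at this position can be read: with the shared core, the cyclopropyl group and the benzyl ester all kept, putting isopropyl in place of the group of 6 heavy atoms on the saturated chain carbon gives, in this assay, a number 10.7 percentage points higher from compound 1 to compound 4 (beyond the scatter). The effect at the one dose given therefore does not depend on the nitrogen-bearing group at this position, since the plain hydrocarbon group keeps the effect and the step is modest but upward. Nothing measured on these compounds speaks to what lies behind this step, so it stands as an observation only.

The compounds shown leave open whether other side chains would follow the same direction, such as a primary amine on a chain of similar length, a longer alkyl chain or a phenyl ring at this position, as a single pair sets no trend. They also leave open what a carboxylic acid in place of the benzyl ester would do with the isopropyl side chain kept, as compound 2 differs from compound 4 in more than one place.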